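Reversing the enone orientation on the shared core

A few compounds are considered here, and "the series" means these few. Any claim that something is new, unique, unknown or untested is made for them only; others in the source may bear on it.

Compound 3 `COc1cc(-c2cc(C(=O)/C=C/c3ccc(C)cc3)nc3cc(-c4ccccc4)nn23)cc(OC)c1OC` gives 18600 nM in a functional assay on MDA-MB-231 cells (Homo sapiens) for antiproliferative activity, read by MTT assay, with a stated time of 24 h (a higher number here means a weaker inhibitor, a lower number a stronger inhibitor), the highest of the three numbers. Its nearest neighbour, compound 2 `COc1ccc(/C=C/C(=O)c2cc(-c3cc(OC)c(OC)c(OC)c3)n3nc(-c4ccccc4)cc3n2)cc1OC`, gives 14200 nM, and the step of a 1.3-fold higher number from compound 2 to compound 3 (0.12 log units; within the scatter) is within the scatter. Compound 1 `COc1ccc(C(=O)/C=C/c2cc(-c3ccc(OC)c(OC)c3)n3nc(-c4ccccc4)cc3n2)cc1OC` gives 2600 nM, a number well below that of compound 3. Compound 4 `COc1cc(-c2cc(/C=C/C(=O)c3ccccc3)nc3cc(-c4ccccc4)nn23)cc(OC)c1OC` carries 2-benzoylethenyl in place of (2-(4-methylphenyl)ethenyl)carbonyl on an aromatic carbon. Within the data shown here, no measured step isolates this change; yet compound 1, whose chain also places the carbonyl beside the outer ring, shows a lower number than compounds 2 and 3, whose carbonyl sits on the core. Compound 4 is therefore expected to give a lower number, a step of a 3.1-fold lower number from compound 3 to compound 4 (0.49 log units; beyond the scatter), with an estimate of 6000 nM in the range 1800 nM to 20000 nM.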

Compound 4, half-maximal inhibitory concentration: 15800 nM
Compound 4: middle estimate off by 2.6-fold (0.42 log units), on the low side, within the range that was stated.
By their numbers in this assay, from the lowest: compound 1; then compounds 2, 4 and 3 (each within the scatter of the next).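

The step to 2-benzoylethenyl at this position, a 1.2-fold lower number from compound 3 to compound 4 (0.07 log units; within the scatter), shows that with the 3,4,5-trimethoxyphenyl group held fixed, this change leaves the two compounds indistinguishable in this assay. The step reverses the chain and also loses the methyl group of the outer ring, so it cannot separate these two differences. No measurement offered here gives a reason for the result. Going by these compounds, it remains open whether an amide or a carboxylic acid in place of this chain would move the number beyond the scatter.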